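Bromine for Fluorine on the Biaryl Acid Core

The compounds below may be only part of what the source reports. "The series", "measured", "known", "first", "only" and "open" are said of these compounds alone.

Compound 1 `CC(=O)Nc1cccc(-c2ccc(C(=O)N(Cc3cccc(OCCCCCC(=O)O)c3)C(C)C)cc2)c1` and compound 2 `CC(C)N(Cc1cccc(OCCCCCC(=O)O)c1)C(=O)c1ccc(-c2cccc(F)c2)cc1` share one core and were both tested in an ADME assay on HepG2 cells (Homo sapiens) for cytotoxicity, read by CellTiter-Glo and resazurin assay, with a stated time of 72 h; on this read-out higher numbers stand for an effect only at larger amounts of compound and lower numbers for an effect already at smaller amounts. In this assay compound 1 gives only a limit of the assay, > 26000 nM, and not a number. Compound 2 likewise gives only a limit, > 26000 nM. The step that the two limits leave unreadable from compound 1 to compound 2 puts fluoro in place of acetamido on an aromatic carbon, and its size cannot be read because both values sit at the limit of > 26000 nM in this assay, at which 2 of the 2 values shown sit. For the measured compounds named here, compound 2 therefore stands at the limit, as does the one further value shown, and nothing places it higher or lower.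

Compound 3 `CC(C)N(Cc1cccc(OCCCCCC(=O)O)c1)C(=O)c1ccc(-c2cccc(Br)c2)cc1` differs from compound 2 by bromo in place of fluoro on an aromatic carbon of a six-membered aromatic ring of carbon only, meta to a large group; cut one bond further out, the change reads 3-fluorophenyl to 3-bromophenyl. Going by the values given here, no readable measured step bears on this change, since the only measured step is unreadable. The expectation is accordingly for no step beyond the scatter, an estimated step that the limit leaves unreadable from compound 2 to compound 3. Compound 3 is expected to give about 30000 nM, within 10000 nM to 90000 nM, most likely again only as a limit.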

Compound 3, half-maximal effective concentration: > 26000 nM
Compound 3 ended at the assay's limit; the forecaster's own chance of this, stated with the estimate: 75%; the middle value is on the limit's open side.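

No new step can be read in this assay from compound 1, compound 2 and compound 3, because each gives only a limit and not a number: the limit of > 26000 nM in this assay, at which 3 of the 3 values shown sit.

The compounds shown leave open whether acetamido, fluoro or bromo on this shared core makes any difference to the concentration at which an effect would appear.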